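This account rests on a few compounds, and the source may have more. Where it says the series, first, only, none or still open, it means among the compounds named here.

In an ADME assay on IMR-90 cells (Homo sapiens) for antiproliferative activity, read by MTT assay, with a stated time of 72 h (a higher number here means a weaker inhibitor, a lower number a stronger inhibitor), compound 1 `O=C1C=C(N2CCC(c3ccccc3)CC2)C(=O)c2c(O)cccc21` gives > 50000 nM, which is a limit of the assay. Compound 2 `O=C1C=C(N2CCC(c3ccc(Cl)cc3)CC2)C(=O)c2c(O)cccc21` gives > 50000 nM, again a limit and not a number. For the measured compounds named here, the only measured step is a step that the two limits leave unreadable from compound 1 to compound 2, with chloro in place of hydrogen on an aromatic carbon. All that is known is the limit of > 50000 nM in this assay, at which 2 of the 2 values shown sit. Compound 3 `Cc1ccccc1C1CCN(C2=CC(=O)c3cccc(O)c3C2=O)CC1` differs from compound 2 by 2-methylphenyl in place of 4-chlorophenyl on a saturated ring carbon, with 2-methylphenyl in place of 4-chlorophenyl on a saturated ring carbon. Going by the values given here, no step of readable size bears on this change, so none beyond the scatter is expected in this assay, in either direction. The estimated step is a number no higher from compound 2 to compound 3 (the limit leaves the size open). Compound 3 is expected at 50000 nM, within an estimated range of 20000 nM to 100000 nM.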

Compound 3, half-maximal inhibitory concentration: > 50000 nM
Compound 3: only a limit was reported; the forecaster's own chance of this, stated with the estimate: 75%; the middle value sits exactly at the limit.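

No step can be read among compound 1, compound 2 and compound 3, which all sit at a limit and not at a number: the limit of > 50000 nM in this assay, at which 3 of the 3 values shown sit. In this assay the compounds shown leave open whether these changes move the value at all.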